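This account rests on a few compounds, and the source may have more. Where it says the series, first, only, none or still open, it means among the compounds named here.

Measured compounds in a functional assay on L1210 cells (Mus musculus) for cytotoxicity, read by cell counting, with a stated time of 2 days; on this read-out higher numbers stand for weaker inhibition and lower numbers for stronger inhibition:
Compound 1, `CC(C)(C)c1ccc(CN2C(=O)S/C(=C\c3cccc(N)c3)C2=O)cc1`, gives 223000 nM.
Compound 2, `Nc1cccc(/C=C2\SC(=O)N(Cc3cccc(Cl)c3)C2=O)c1`, gives 211000 nM.
Compound 3, `Nc1cccc(/C=C2\SC(=O)N(Cc3ccc(C(F)(F)F)cc3)C2=O)c1`, reaches only a limit of the assay, > 250000 nM.

All three share one core and differ in a single group on an aromatic carbon. Compound 3 stands at the edge of what this assay can report: for it there is only a limit, no number, and (the limit of > 250000 nM in this assay, at which 1 of the 3 values shown sits). Among the measured compounds shown here, the one measured step that touches this position is an at least 1.1-fold higher number from compound 1 to compound 3 (0.04 log units; that floor lies within the scatter), where trifluoromethyl took the place of tert-butyl on an aromatic carbon; because that step ends at a limit, it too is only a floor, and a small one. Compound 1 and compound 2 give numbers within the scatter of each other.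

Compound 4, `Nc1cccc(/C=C2\SC(=O)N(Cc3ccccc3)C2=O)c1`, carries the next change at the same spot: hydrogen in place of trifluoromethyl on an aromatic carbon. For the measured compounds named here, no measured step separates trifluoromethyl from hydrogen here, so the expected change, an at least 1.0-fold lower number from compound 3 to compound 4 (0.03 log units; that floor lies within the scatter), stays within the scatter. Compound 4 is therefore estimated at 230000 nM, with a range from 120000 nM to 450000 nM, and a fair chance that the assay again reports only a limit.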

Compound 4, half-maximal inhibitory concentration: 233000 nM
Estimate against measurement, compound 4: 1.0-fold (0.01 log units) below; measured number inside the range.
By their numbers in this assay, from the lowest: compounds 2, 1 and 4 (each within the scatter of the next). At a limit, above all of these: compound 3.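

Among the compounds shown here, compound 4 adds the plain ring with hydrogen on this carbon, a reference the earlier compounds did not offer, and taking the group away changes nothing that can be told apart: hydrogen in place of chloro gives a 1.1-fold higher number from compound 2 to compound 4 (0.04 log units; within the scatter), hydrogen in place of tert-butyl gives a 1.0-fold higher number from compound 1 to compound 4 (0.02 log units; within the scatter), and hydrogen in place of trifluoromethyl gives an at least 1.0-fold lower number from compound 3 to compound 4 (0.03 log units; that floor lies within the scatter). In this assay, then, compound 1, compound 2 and compound 4 show no sign that having one of these groups on the ring matters, whether it is large like tert-butyl or a single chloro atom. Compound 3 is the one compound that cannot join this pattern, since it has a limit and not a number, and so the step that starts from it cannot be read as a size: the limit of > 250000 nM in this assay, at which 1 of the 4 values shown sits.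

The compounds shown leave open whether any group on this ring can move the number beyond the scatter, as an amine, a carboxylic acid or a longer chain in this place might or might not do. They also leave open how far trifluoromethyl truly stands from hydrogen, which only a number for compound 3 could settle.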